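A few compounds are considered here, and "the series" means these few. Any claim that something is new, unique, unknown or untested is made for them only; others in the source may bear on it.

The measured compounds:
compound 1, `O=C(NCC1CCCN(CCCc2ccccc2)C1)c1ccccc1-c1ccccc1`, 100000000 nM
compound 2, `O=C(Nc1ccccc1)c1ccccc1-c1ccccc1`, 10700 nM
compound 3, `COc1ccc(CC2CC(=O)N(c3ccccc3C(=O)OCC3CCCN(CCCc4ccccc4)C3)C2=O)cc1`, 28800 nM

These values come from an in vitro functional assay on HEK ts201 cells for antagonist activity at Neuronal acetylcholine receptor; alpha3/beta4 (Homo sapiens), read by fluorescence and calcium flux; a lower number here means a stronger inhibitor, a higher number a weaker inhibitor. Among the three, compound 3 stands second highest. Its nearest neighbour is compound 2, which gives a lower number in this assay, a gap beyond the usual scatter. Compound 1 stands furthest away, with a number far higher than that of compound 3, again well beyond the scatter.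

Compound 4, `O=C(OCC1CCCN(CCCc2ccccc2)C1)c1ccccc1N1C(=O)CC(Cc2ccc(Cl)cc2)C1=O`, has not yet been measured. It differs from compound 3 in one place: chloro in place of methoxy on an aromatic carbon. For the measured compounds named here, no step between two measured compounds shows what this exchange does, so there is no measured reference for it. On the information shown, the change is expected to shift the result of compound 4 in this assay only modestly, if at all, with no direction favoured beyond the scatter. Compound 4 is therefore expected to give about 25000 nM in this assay, with a range from 8000 nM to 80000 nM. This estimate means an expected step of a 1.2-fold lower number from compound 3 to compound 4 (0.06 log units; within the scatter) that stays close to the scatter.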

Compound 4, half-maximal inhibitory concentration: 14500 nM
Compound 4: middle estimate off by 1.7-fold (0.24 log units), on the high side; measured number inside the range.
By their numbers in this assay, from the lowest: compounds 2, 4 and 3 (each within the scatter of the next, the first and the last beyond it); then compound 1.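

In this assay, chloro in place of methoxy on an aromatic carbon para to a large group gives a 2.0-fold lower number from compound 3 to compound 4 (0.30 log units; within the scatter), a step that stays within the usual scatter. This is the first measured step among these compounds, and it shows that going from 4-methoxybenzyl to 4-chlorobenzyl, which removes the hydrogen-bond acceptor of the methoxy group, produces no change that can be told from the scatter. Nothing available here bears on the reason for this result.

On these data alone, the two compounds cover only methoxy and chloro at this position, so it remains open whether an amine, a carboxylic acid or a nitrile there would stay within the scatter of compound 3. As far as these compounds go, it is also open whether a longer chain carrying this aromatic ring would keep the number in the same range.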